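Replacing the 4-methoxyphenyl group of compound 3

This account rests on a few compounds, and the source may have more. Where it says the series, first, only, none or still open, it means among the compounds named here.

Compound 1 `Cc1cc(C)cc(SCc2ccc(/C=C/C(=O)Nc3ccccc3N)cc2)c1` gives 8.61% here
Compound 2 `Nc1ccccc1NC(=O)/C=C/c1ccc(CSc2cccc(F)c2)cc1` gives 8.56% here
Compound 3 `COc1ccc(SCc2ccc(C(=O)Nc3ccccc3N)cc2)cc1` gives 33.1% here

These numbers come from a functional assay on SMMC-7721 cells (Homo sapiens) for inhibition, read by CCK-8 assay, with a stated time of 72 h, tested at 2 uM (on this read-out lower numbers stand for less inhibition of growth and higher numbers for more inhibition of growth at the one concentration tested), and compound 3 stands highest of the three, beyond the scatter of the other two, which lie within the scatter of each other. Among the compounds with values here, compound 4 `Nc1ccccc1NC(=O)c1ccc(CSc2cccc(F)c2)cc1` keeps the core of compound 3 and differs by 3-fluorophenyl in place of 4-methoxyphenyl on a sulfur as its only change. Within the data shown here, one measured step bears on this: a number 0.1 percentage points lower from compound 1 to compound 2 (within the scatter) shows a 3-fluorophenyl group taking over on a sulfur with no change beyond the scatter. Among the measured compounds shown here, that step sits on the core of compound 1, which is not the core of compound 3, and no measured step removes a 4-methoxyphenyl group, so the evidence is thin. Little change is therefore expected, with no firm direction, and the estimated step is a number 3.1 percentage points lower from compound 3 to compound 4 (within the scatter) on this thin basis. Compound 4 is estimated at 30% with an expected range from 12% to 55% in this test.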

Compound 4, percent growth inhibition at one concentration: 18.6%
Estimate against measurement, compound 4: 11.4 percentage points above; measured number inside the range.
By their numbers in this assay, from the lowest: compounds 2, 1 and 4 (each within the scatter of the next); then compound 3.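

In this assay, putting 3-fluorophenyl in place of 4-methoxyphenyl on a sulfur gives a number 14.5 percentage points lower from compound 3 to compound 4 (beyond the scatter), so on this core the choice of group at this place does count. The earlier swap on the core of compound 1 gave a number 0.1 percentage points lower from compound 1 to compound 2 (within the scatter), with the same group entering but 3,5-dimethylphenyl leaving, so a quiet result there did not predict a quiet result here. Nothing shown here accounts for the loss of growth inhibition.

Going by these compounds, it remains open whether the loss follows from losing the 4-methoxyphenyl group or from bringing in the 3-fluorophenyl group. A plain phenyl, a 4-fluorophenyl or a 3-methoxyphenyl group on the same sulfur would help to separate these two readings.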